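Swapping the Group on the Benzimidazole-Side Chain Carbon

The source may report more compounds than this note shows. Statements on the series, on what has been measured and on what is new or still open speak of the compounds shown alone.

Compound 1 `CC(C)CCn1c(CN2CCN(C(=O)C3CC3)CC2)nc2ccccc21` is the reference point here. In an assay on isolated protein for inhibition of aldehyde dehydrogenase 1A1 (Homo sapiens), read by spectrophotometry, tested at 10 uM (a lower number here means less inhibition, a higher number more inhibition at the concentration tested (going by the name of the read-out)), compound 1 gives 70%. Compound 2 `O=C(C1CC1)N1CCN(Cc2nc3ccccc3n2CC2CC2)CC1` differs from it in one place, and in this assay compound 2 gives 21.2%. Within the data shown here, the step of a number 48.8 percentage points lower from compound 1 to compound 2 (beyond the scatter) is the only measured step, so compound 2 stands at the bottom of the two numbers, with compound 1 the nearest and higher neighbour.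

Compound 3 `O=C(C1CC1)N1CCN(Cc2nc3ccccc3n2Cc2ccc(C(F)(F)F)cc2)CC1` is not yet measured. It differs from compound 2 by 4-(trifluoromethyl)phenyl in place of cyclopropyl on a saturated chain carbon bound to an aromatic nitrogen. This change touches the same saturated chain carbon bound to an aromatic nitrogen that the step from compound 1 to compound 2 altered, so that step is the only one that bears on it, and it was large. The entering group is a six-membered aromatic ring of carbon only carrying a trifluoromethyl, whereas the leaving group is a three-membered non-aromatic ring; nothing measured shows how an aromatic group at this carbon behaves, so the estimate is uncertain. The step of a number 33.8 percentage points higher from compound 2 to compound 3 (beyond the scatter) is expected to lead back upward. Compound 3 is estimated at 55%, within 25% to 85%.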

Compound 3, a percentage reported as inhibition, at one concentration (the size of the read-out at that concentration, not a potency): 37%
Estimate against measurement, compound 3: 18 percentage points above; low and high end bracket the measured number.
By their numbers in this assay, from the lowest: compound 2; then compound 3; then compound 1.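

In this assay, among these compounds, the step of a number 15.8 percentage points higher from compound 2 to compound 3 (beyond the scatter) gives the first reading for an aromatic group on this saturated chain carbon bound to an aromatic nitrogen: 4-(trifluoromethyl)phenyl, with 10 heavy atoms, gives more inhibition at the tested concentration than cyclopropyl, with 3. The step of a number 33 percentage points lower from compound 1 to compound 3 (beyond the scatter) shows that this aromatic group still does not reach the level of the open-chain isobutyl, so a larger group at this carbon does not by itself bring the number back to that of compound 1. Nothing available gives a reason for this order among the three groups.

The compounds shown leave open how much of the rise from cyclopropyl belongs to the six-membered ring and how much to the trifluoromethyl on it, a question that a plain phenyl at this carbon could help settle. They also leave open whether a chain longer than isobutyl, or a chain ending in an amine, would match or pass compound 1 in this assay.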